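A few compounds are considered here, and "the series" means these few. Any claim that something is new, unique, unknown or untested is made for them only; others in the source may bear on it.

Measured so far in a functional assay on MDA-MB-468 cells (Homo sapiens) for inhibition; on this read-out higher numbers stand for weaker inhibition and lower numbers for stronger inhibition:
- compound 1, `Cc1cc(N)ccc1-c1nc2ccccc2s1`: compound 1 gives < 0.1 nM; < 0.1 nM (2 entries), which is a limit of the assay and not a number.
- compound 2, `CCc1cc(N)ccc1-c1nc2ccccc2s1`: compound 2 gives < 0.1 nM, again a limit.
- compound 3, `Nc1ccc(-c2nc3ccccc3s2)c(Br)c1`: compound 3 gives < 0.1 nM, also a limit.

Compound 3 therefore stands only at a limit in this assay. The other values shown are limits as well, so the numbers do not separate compound 3 from compound 1 or compound 2. For the measured compounds named here, the one step available, a step that the two limits leave unreadable from compound 2 to compound 3, bromo in place of ethyl on an aromatic carbon, cannot be read in size because both of its ends sit at the limit of < 0.1 nM in this assay, at which 2 of the 3 values shown sit.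

Compound 4, `Cc1ccc2nc(-c3ccc(N)cc3Br)sc2c1`, differs from compound 3 by methyl in place of hydrogen on an aromatic carbon. Going by the values given here, no measured step touches the ring that is part of a fused or bridged system of two rings, so no step bears directly on this change; the only step is unreadable in any case. Nothing in the data points to a shift beyond the scatter in this assay in either direction.

Compound 4 is expected to give 0.05 nM in this assay, with a range from 0.01 nM to 0.3 nM, most likely reported once more only as a limit. The step that the limit leaves unreadable from compound 3 to compound 4 is thus estimated as none beyond the scatter.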

Compound 4, half-maximal inhibitory concentration: < 0.1 nM
Compound 4 was reported as a limit; the forecaster's own chance of this, stated with the estimate: 80%; the middle value does not contradict the limit.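

Compound 3 and compound 4 both stand only at a limit in this assay, so no new step can be read between them: the limit of < 0.1 nM in this assay, at which 3 of the 4 values shown sit. The compounds shown leave open whether methyl in place of hydrogen or bromo in place of ethyl on an aromatic carbon changes inhibition at all, and by how much.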